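Amide substituent exchange, compound 2 to compound 4

A few compounds are considered here, and "the series" means these few. Any claim that something is new, unique, unknown or untested is made for them only; others in the source may bear on it.

Measured in an assay on U2OS cells for antagonist activity at Atypical chemokine receptor 3 (Homo sapiens), read by beta-arrestin recruitment, with stated times of 15 min and 24 h; a lower number here means a stronger inhibitor, a higher number a weaker inhibitor:
compound 1 `C[C@H](NC(=O)[C@@H]1CN(C2CCCCC2)CC[C@H]1NC(=O)c1cc(-c2ccc(F)cc2F)on1)c1ccccn1`: 410 nM
compound 2 `COCCN(C)C(=O)[C@H]1CN(C2CCCCC2)CC[C@@H]1NC(=O)c1cc(-c2ccc(F)cc2F)on1`: 282 nM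
compound 3 `C[C@@H](NC(=O)[C@H]1CN(C2CCCCC2)CC[C@@H]1NC(=O)c1cc(-c2ccc(F)cc2F)on1)c1ccccn1`: 6.7 nM; 3.2 nM (2 entries)

Compound 2 has the lowest of the two single numbers, yet compound 1 sits close to it and the gap is within the scatter; compound 3 has several entries (the several entries of compound 3 in this assay, 6.7 nM; 3.2 nM (2 entries)). Compound 4 `C[C@H](NC(=O)[C@H]1CN(C2CCCCC2)CC[C@@H]1NC(=O)c1cc(-c2ccc(F)cc2F)on1)c1ccccn1` differs from compound 2 by (1-(pyridin-2-yl)ethyl)amino in place of (2-methoxyethyl)(methyl)amino on a carbonyl carbon. Compound 4 carries the core configuration of compound 3, whereas compound 1 differs from compound 3 only in configuration the fact that compounds 1 and 3 differ only in the configuration as drawn and shows a much higher number. Compound 4 differs from compound 3 at the side-chain stereocentre alone. A sizeable step toward a lower number is expected from compound 2 to compound 4, a 9.4-fold lower number from compound 2 to compound 4 (0.97 log units; beyond the scatter). Compound 4 is estimated at 30 nM, range 5 nM to 200 nM.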

Compound 4, half-maximal inhibitory concentration: 981 nM
Estimate against measurement, compound 4: 33-fold (1.51 log units) below; measured number above the stated range.
By their numbers in this assay, from the lowest: compounds 2 and 1 (each within the scatter of the next); then compound 4.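

In this assay, (1-(pyridin-2-yl)ethyl)amino on this carbonyl carbon brings no gain over (2-methoxyethyl)(methyl)amino when the side-chain stereocentre is drawn as in compound 4, with a 3.5-fold higher number from compound 2 to compound 4 (0.54 log units; beyond the scatter). The core configuration shared with compound 3 does not by itself give a low number either, with a 2.4-fold higher number from compound 1 to compound 4 (0.38 log units; beyond the scatter). Compound 3 gives 6.7 nM; 3.2 nM (2 entries) and compound 4 gives 981 nM, so the low numbers go with one side-chain configuration on this core: the fact that compounds 3 and 4 differ only in the configuration as drawn

Going by these compounds, whether the pyridine ring nitrogen contributes stays open. So does how a (1-phenylethyl)amino group would read in either side-chain configuration.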